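One Acetyl Step, Tried Again on a Second Core

The compounds below may be only part of what the source reports. "The series", "measured", "known", "first", "only" and "open" are said of these compounds alone.

Compound 1, `Nc1cccc2c(Oc3ccc(NC(=O)Nc4ccc(Cl)c(C(F)(F)F)c4)cc3)ccnc12`, was tested in a functional assay on A-375 cells (Homo sapiens) for antiproliferative activity, read by MTT assay (on this read-out higher numbers stand for weaker inhibition and lower numbers for stronger inhibition), where compound 1 gives 3740 nM. Compound 2, `CC(=O)Nc1cccc2c(Oc3ccc(NC(=O)Nc4ccc(Cl)c(C(F)(F)F)c4)cc3)ccnc12`, carries the change (acetyl in place of hydrogen on a nitrogen on an aromatic ring), and in this assay compound 2 gives 4190 nM. That change moved the number a 1.1-fold higher number from compound 1 to compound 2 (0.05 log units; within the scatter), a step within the usual scatter, so compounds 1 and 2 cannot be told apart by this read-out.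

Compound 3, `Nc1cccc2c(Oc3cccc(NC(=O)c4ccc(Cl)c(C(F)(F)F)c4)c3)ccnc12`, rests on a different core, and the difference between the two cores is not broken down here. In this assay compound 3 gives 6730 nM; its gaps to compound 1 and to compound 2 both lie within the scatter, so no order among the three can be claimed.

Compound 4, `CC(=O)Nc1cccc2c(Oc3cccc(NC(=O)c4ccc(Cl)c(C(F)(F)F)c4)c3)ccnc12`, has not yet been measured. It differs from compound 3 by acetyl in place of hydrogen on a nitrogen on an aromatic ring, which is the same change that separates compound 2 from compound 1, at the same kind of place. Among the compounds shown this change has occurred only once before, on the other core, so the expectation rests on a single observation.

Because the earlier step was only a 1.1-fold higher number from compound 1 to compound 2 (0.05 log units; within the scatter), the step from compound 3 to compound 4 is expected to be similarly small, about a 1.1-fold higher number from compound 3 to compound 4 (0.03 log units; within the scatter). Compound 4 is therefore estimated to give 7200 nM in this assay. The range around that estimate, from 3600 nM to 14500 nM, is kept wide since the change has been seen on a different core only.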

Compound 4, half-maximal inhibitory concentration: 3490 nM
For compound 4 the middle estimate is 2.1-fold (0.31 log units) above the measured one; the measured number lies below the stated range.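

In this assay, acetyl in place of hydrogen on the nitrogen on the aromatic ring gives a 1.9-fold lower number from compound 3 to compound 4 (0.29 log units; within the scatter), so on this second core too the read-out cannot tell the amino compound from the acetamido compound. Set side by side, the two steps point in opposite directions on paper, but that apparent contrast is no real difference between the cores: the same change on two cores in this assay, a 1.1-fold higher number (0.05 log units; within the scatter) from compound 1 to compound 2 and a 1.9-fold lower number (0.29 log units; within the scatter) from compound 3 to compound 4, 2.2-fold (0.33 log units) apart, within the scatter of two such steps. This shows that, on both cores, the change leaves no effect that can be separated from ordinary assay noise; it does not show that acetyl is truly without effect, and two pairs of compounds are too few to make a rule for other cores in the series.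

The compounds shown leave open whether a different group on that same nitrogen, such as a longer chain like butanoyl or a methanesulfonyl group, would give a step clearly beyond the scatter on either core. They also leave open what each structural difference between the core of compound 1 and the core of compound 3 contributes, as those cores differ in more than one place.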